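This account rests on a few compounds, and the source may have more. Where it says the series, first, only, none or still open, it means among the compounds named here.

Measured so far:
Compound 1 `COC(=O)c1ccc(N(Cc2ccc(C3CCCCC3)cc2)C(=O)[C@H]2CCN2S(=O)(=O)c2c(F)c(F)c(F)c(F)c2F)c(F)c1`: 4400 nM
Compound 2 `COC(=O)c1ccc(N(Cc2cnc(C3CCCCC3)cn2)C(=O)[C@H]2CCN2S(=O)(=O)c2c(F)c(F)c(F)c(F)c2F)c(F)c1`: 1400 nM

Both numbers come from a functional assay on MDA-MB-231 cells (Homo sapiens) for antiproliferative activity, with a stated time of 72 h; a lower number here means that less compound is needed, a higher number that more compound is needed for the effect. For the measured compounds named here, of the two measured compounds, compound 1 stands at the higher number, and its only neighbour is compound 2, reached by a change on the saturated chain carbon bound to the amide-type nitrogen: a 3.1-fold lower number from compound 1 to compound 2 (0.50 log units; beyond the scatter). Going by the values given here, that is the only measured step available.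

Compound 3 `O=C([C@H]1CCN1S(=O)(=O)c1c(F)c(F)c(F)c(F)c1F)N(Cc1ccc(C2CCCCC2)cc1)c1ccc2c(=O)[nH]ncc2c1` has not yet been measured in this assay. It differs from compound 1 at another place, on the amide-type nitrogen itself: a group of 11 heavy atoms (8 carbon, 2 nitrogen, 1 oxygen; one six-membered aromatic ring of carbon only, one six-membered aromatic ring with 2 hetero atoms) in place of a group of 11 heavy atoms (8 carbon, 2 oxygen, 1 fluorine; one six-membered aromatic ring of carbon only), on an amide-type nitrogen

The measured step from compound 1 to compound 2 altered a different part of the molecule, so it gives no direct guide to this change; it only shows that a single exchange of a ring in this series has so far moved the number by a modest amount. With no closer comparison, a step of modest size in either direction is the most that can be expected, and the estimate for compound 3 is therefore set near compound 1 with a wide range: compound 3 is expected to give 3500 nM, between 900 nM and 14000 nM. The expected step is a 1.3-fold lower number from compound 1 to compound 3 (0.10 log units; within the scatter).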

Compound 3, half-maximal effective concentration: 1600 nM
Compound 3: the middle estimate sits 2.2-fold (0.34 log units) above what was measured, within the range that was stated.
By their numbers in this assay, from the lowest: compounds 2 and 3 (each within the scatter of the next); then compound 1.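

In this assay, the exchange on the amide-type nitrogen gives a 2.8-fold lower number from compound 1 to compound 3 (0.44 log units; beyond the scatter) and so shows that this position, and not only the 4-cyclohexylphenyl group changed in compound 2, can shift the number by more than the scatter. The step comes without a change in size as counted by heavy atoms, since the group that leaves and the group that enters have the same count, but the entering group differs in kind: the 2-fluoro-4-(methoxycarbonyl)phenyl group gives way to a fused pair of aromatic rings with 2 nitrogen atoms and 1 hydrogen-bond donor, where the group that leaves has 0 donors. No measurement is available that ties the step to any one of these differences.

From the compounds shown here alone, it remains open whether the loss of the methyl ester, the loss of the fluorine or the arrival of the second ring matters most, and a plain phenyl group or a 4-carboxyphenyl group on the same nitrogen would help to separate these. Going by these compounds, it is also open whether the 5-cyclohexylpyrazin-2-yl group and the group of compound 3 would add up when carried together in one molecule.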